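This account rests on a few compounds, and the source may have more. Where it says the series, first, only, none or still open, it means among the compounds named here.

Measured so far in an ADME assay on the whole organism (Rattus norvegicus, strain Wistar Han) for pharmacokinetics, read by LC-MS, with a stated time of 7 h, at a dose of 1 mg/kg by the intravenous route; on this read-out higher numbers stand for fast clearance and lower numbers for slow clearance:
Compound 1 `CCNC(=O)c1cc(C(=O)NC)c(=O)n(Cc2ccccc2)c1`: 12 mL/min/kg
Compound 2 `CNC(=O)c1cc(C(=O)NC2CC2)cn([C@H](C)c2ccccc2)c1=O`: 72 mL/min/kg
Compound 3 `CNC(=O)c1cc(C(=O)NC2CC2)cn(Cc2cccc3[nH]ccc23)c1=O`: 23 mL/min/kg

Clearance describes how quickly the body removes a compound from the blood. Compound 3, at 23 mL/min/kg, cannot be told apart from compound 1, at 12 mL/min/kg, as the two values lie within the usual scatter of repeated measurements. Compound 2, at 72 mL/min/kg, is higher than compound 3 by more than that scatter.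

Compound 4 `CNC(=O)c1cc(C(=O)NC2CC2)cn(Cc2cccc([C@@H](C)O)c2)c1=O` differs from compound 3 in one place: 3-(1-hydroxyethyl)phenyl in place of 1H-indol-4-yl on a saturated chain carbon bound to an aromatic nitrogen. In words, this puts 3-(1-hydroxyethyl)phenyl in place of 1H-indol-4-yl on a saturated chain carbon bound to an aromatic nitrogen. Going by the values given here, no pair of measured compounds differs in only one place, so the data give no direct guide to the size of this step. The best starting point is therefore compound 3 at 23 mL/min/kg, with a wide margin on both sides. A small rise is expected, most likely none beyond the scatter. The estimate amounts to a 1.3-fold higher number from compound 3 to compound 4 (0.12 log units; within the scatter). The clearance expected for compound 4 is 30 mL/min/kg, with an estimated range of 12 mL/min/kg to 70 mL/min/kg.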

Compound 4, clearance: 74 mL/min/kg
Estimate against measurement, compound 4: 2.5-fold (0.39 log units) below, and the stated range ends below it.
By their numbers in this assay, from the lowest: compounds 1 and 3 (each within the scatter of the next); then compounds 2 and 4 (each within the scatter of the next).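

In this assay, placing 3-(1-hydroxyethyl)phenyl in place of 1H-indol-4-yl on a saturated chain carbon bound to an aromatic nitrogen gives a 3.2-fold higher number from compound 3 to compound 4 (0.51 log units; beyond the scatter). Going by these compounds alone, this is the only comparison here that changes a single place, and it shows that the group held at this position can move clearance by more than the usual scatter of the measurement. The two groups have the same count of heavy atoms and each has a hydrogen-bond donor, so those two counts alone do not predict the result, and no measurement available here accounts for the rise.

The change alters several features together, replacing the five-membered aromatic ring with a one-ring group that carries an oxygen and a defined stereocentre, and the compounds shown do not separate their contributions. Still open, on these data alone, are the opposite stereoisomer of the 1-hydroxyethyl group and how clearance would respond to a different group on the phenyl ring, such as a carboxylic acid or an aminomethyl group.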